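The compounds below may be only part of what the source reports. "The series", "measured", "known", "first", "only" and "open" are said of these compounds alone.

The measured compounds and their numbers in a functional assay on HEK293 cells for antagonist activity at transient receptor potential cation channel subfamily V member 1 (Rattus norvegicus); a higher number here means a weaker inhibitor, a lower number a stronger inhibitor:

compound 1, `Cc1ccc(NC(=O)N2CCN(c3ncccc3C(F)(F)F)CC2)cc1`: 556 nM
compound 2, `CC(C)c1ccc(NC(=O)N2CCN(c3ncccc3Cl)CC2)cc1`: 11.5 nM
compound 3, `CCCCc1ccc(NC(=O)N2CCN(c3ncccc3Cl)CC2)cc1`: 117 nM

Compound 3 stands second highest of these three numbers. Its nearest neighbour is compound 1, which gives a higher number, and its furthest is compound 2, which gives the lowest number of the set.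

Compound 4, `O=C(Nc1ccc(C(F)(F)F)cc1)N1CCN(c2ncccc2Cl)CC1`, differs from compound 3 in a single place: trifluoromethyl in place of butyl on an aromatic carbon. Among the measured compounds shown here, only one measured step touches this same position: a 10-fold higher number from compound 2 to compound 3 (1.01 log units; beyond the scatter), a large change from a single exchange of the group on that aromatic carbon. For the measured compounds named here, that step shows the group at this carbon can move the read-out by a large amount, but no measured pair exchanges a chain for trifluoromethyl, so the direction for compound 4 cannot be read directly from the data. Because compound 2 gives 11.5 nM with a different group at the same carbon while compound 3 gives 117 nM, a group other than butyl at that position is expected to be able to lower the number again. Compound 4 is therefore expected to show a 2.9-fold lower number from compound 3 to compound 4 (0.47 log units; beyond the scatter) in this assay, with wide uncertainty. The estimate for compound 4 is 40 nM, within a range of 10 nM to 200 nM.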

Compound 4, half-maximal inhibitory concentration: 63.5 nM
Estimate against measurement, compound 4: 1.6-fold (0.20 log units) below; measured number inside the range.
By their numbers in this assay, from the lowest: compound 2; then compounds 4 and 3 (each within the scatter of the next); then compound 1.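

In this assay, exchanging butyl for trifluoromethyl on this aromatic carbon gives a 1.8-fold lower number from compound 3 to compound 4 (0.27 log units; within the scatter), so these two groups, with their equal count of heavy atoms but different atoms, cannot be told apart here. Isopropyl now stands apart from both of them: the exchange for trifluoromethyl gives a 5.5-fold higher number from compound 2 to compound 4 (0.74 log units; beyond the scatter), which adds a second step beyond the scatter to the earlier 10-fold higher number from compound 2 to compound 3 (1.01 log units; beyond the scatter), and among the three compounds that differ only at this carbon, compound 2 gives the lowest number. The large effect at this position is therefore tied to isopropyl in particular among these groups, but nothing shown here explains why it differs from butyl and trifluoromethyl.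

The compounds shown leave open how a tert-butyl group, a propyl chain or a methoxy group would behave on this carbon, and so whether the advantage extends beyond isopropyl itself. They also leave open what a methyl group does here with the rest of the molecule held constant, as compound 1 differs from the others in two places.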